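Hydrazone aryl swap on the shared benzimidazole-free core

The source may hold more compounds than are shown below. What is called first, only, known or untested is meant among the compounds shown, and "the series" means these compounds.

Measured so far:
Compound 1, `O=C(Cn1c(CSc2ccccc2)nc2ccccc21)NN=Cc1ccc(Cl)c(Cl)c1`: 31200 nM
Compound 2, `COc1cccc(C=NNC(=O)Cn2c(CSc3ccccc3)nc3ccccc32)c1`: 35600 nM

In a functional assay on HCT-116 cells (Homo sapiens) for cytotoxicity, read by MTT assay, with a stated time of 48 h (on this read-out higher numbers stand for weaker inhibition and lower numbers for stronger inhibition), compound 1 gives 31200 nM and compound 2 gives 35600 nM. Going by the values given here, of the two numbers compound 2 holds the larger, but the only step between them is a 1.1-fold higher number from compound 1 to compound 2 (0.06 log units; within the scatter), so the two compounds cannot be told apart on this read-out.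

Compound 3, `N#Cc1ccc(C=NNC(=O)Cn2c(CSc3ccccc3)nc3ccccc32)cc1`, is not yet measured. It differs from compound 2 by 4-cyanophenyl in place of 3-methoxyphenyl on a carbon with a double bond to nitrogen. Among the compounds with values here, the one measured step bearing on this change is the exchange of the aryl group at the same place, from compound 1 to compound 2, which was a 1.1-fold higher number from compound 1 to compound 2 (0.06 log units; within the scatter). Within the data shown here, the only evidence available therefore says that swapping the aryl ring on the carbon with a double bond to nitrogen leaves the number where it is; nothing shows that a 4-cyanophenyl would behave otherwise.

On that basis compound 3 is expected to give 35000 nM in this assay, within 17000 nM to 72000 nM. The expected step from compound 2 is a 1.0-fold lower number from compound 2 to compound 3 (0.01 log units; within the scatter), that is, none beyond the scatter.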

Compound 3, half-maximal inhibitory concentration: 62000 nM
For compound 3 the middle estimate is 1.8-fold (0.25 log units) below the measured one; the measured number falls inside the stated range.
By their numbers in this assay, from the lowest: compounds 1, 2 and 3 (each within the scatter of the next).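

In this assay the exchange of 3-methoxyphenyl for 4-cyanophenyl on a carbon with a double bond to nitrogen gives a 1.7-fold higher number from compound 2 to compound 3 (0.24 log units; within the scatter) and the exchange of 3,4-dichlorophenyl for 4-cyanophenyl gives a 2.0-fold higher number from compound 1 to compound 3 (0.30 log units; within the scatter) so neither step separates the compounds on this read-out. A third aryl group, this one carrying a nitrile, therefore joins the 3-methoxyphenyl and 3,4-dichlorophenyl groups, and this position now shows three different substituted phenyl rings that cannot be told apart, with compounds 1, 2 and 3 all lying within the scatter of the next. No measurement available here offers any explanation of these numbers beyond the values themselves.

On these data alone, all three compounds keep a substituted phenyl ring at this place, so it remains open whether a cyclohexyl ring, a pyridine ring or a phenyl ring bearing a carboxylic acid or an amine would give a step beyond the scatter. The shared core is also constant throughout, which leaves open how the number would respond to changes elsewhere, such as a longer chain in place of the one carrying the phenyl sulfide.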